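Methoxy for fluoro in a sulfonamide pair

This account rests on a few compounds, and the source may have more. Where it says the series, first, only, none or still open, it means among the compounds named here.

Measured in a functional assay on K562 cells (Homo sapiens) for cytotoxicity, read by trypan blue exclusion, with a stated time of 96 h; on this read-out higher numbers stand for weaker inhibition and lower numbers for stronger inhibition:
- compound 1 `COc1ccc(/C=C/S(=O)(=O)Nc2ccc(OC)c(F)c2)cc1`: 1000 nM
- compound 2 `COc1ccc(/C=C/S(=O)(=O)Nc2ccc(F)cc2)cc1`: 10000 nM

Compound 2, at 10000 nM, holds the higher of the two numbers and so shows the weaker inhibition. The gap to compound 1, at 1000 nM, lies beyond the usual scatter. The next compound to be tested is compound 3 `COc1ccc(/C=C/S(=O)(=O)Nc2ccc(OC)cc2)cc1`, which has methoxy in place of fluoro on an aromatic carbon, para to a large group (methoxy in place of fluoro on an aromatic carbon). Among the compounds with values here, no measured pair isolates this change. The expectation rests on compound 1, which also carries methoxy at that place and reads 1000 nM. The estimated step, a 3.3-fold lower number from compound 2 to compound 3 (0.52 log units; beyond the scatter), points to a lower number and lies beyond the scatter. For compound 3 the expected value in this assay is 3000 nM, with an estimated range of 600 nM to 10000 nM.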

Compound 3, half-maximal inhibitory concentration: 5000 nM
Estimate against measurement, compound 3: 1.7-fold (0.22 log units) below; low and high end bracket the measured number.
By their numbers in this assay, from the lowest: compound 1; then compounds 3 and 2 (each within the scatter of the next).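

In this assay methoxy in place of fluoro on an aromatic carbon, para to a large group, gives a 2.0-fold lower number from compound 2 to compound 3 (0.30 log units; within the scatter) and so does not separate these two groups at this position. The clearer difference comes with hydrogen in place of fluoro on an aromatic carbon, which gives a 5.0-fold higher number from compound 1 to compound 3 (0.70 log units; beyond the scatter) and shows that methoxy at this position does not by itself carry the value of compound 1, since compound 3 has the methoxy but lacks that fluoro. Nothing available gives a reason for either step.

On these data alone, whether an ethoxy or an amine at the position para to the large group would move the number beyond the scatter remains open. As far as these compounds go, it is also open whether a chloro in place of the fluoro of compound 1 would hold its value.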